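A few compounds are considered here, and "the series" means these few. Any claim that something is new, unique, unknown or untested is made for them only; others in the source may bear on it.

In a functional assay on HepG2 cells (Homo sapiens) for antiproliferative activity, read by MTT assay, with a stated time of 48 h (on this read-out higher numbers stand for weaker inhibition of growth and lower numbers for stronger inhibition of growth), compound 1 `CCN(Cc1ccc(C(=O)NO)cc1)c1ncc(-c2ccc(C)cc2)s1` gives 1120 nM, compound 2 `CCCCCCCCN(Cc1ccc(C(=O)NO)cc1)c1ncc(-c2ccc(C)cc2)s1` gives 8760 nM and compound 3 `Cc1ccc(-c2cnc(N(CCCCOc3ccccc3)Cc3ccc(C(=O)NO)cc3)s2)cc1` gives 16600 nM. These compounds share a core and differ only in the chain on the nitrogen. Compound 3 stands at the weak end together with compound 2, the gap being a 1.9-fold higher number from compound 2 to compound 3 (0.28 log units; within the scatter).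

Compound 4 `CCCN(Cc1ccc(C(=O)NO)cc1)c1ncc(-c2ccc(C)cc2)s1` trims the 4-phenoxybutyl chain to propyl: hydrogen in place of phenoxymethyl on a saturated chain carbon, three bonds along the chain from a nitrogen on an aromatic ring, with hydrogen in place of phenoxymethyl on a saturated chain carbon, three bonds along the chain from a nitrogen on an aromatic ring.

Within the data shown here, two measured steps bear on this change when read in reverse: a 15-fold higher number from compound 1 to compound 3 (1.17 log units; beyond the scatter) and a 7.8-fold higher number from compound 1 to compound 2 (0.89 log units; beyond the scatter). Both show that larger chains came with higher numbers, and propyl is far closer in size to the chain of compound 1. Among the measured compounds shown here, no measured compound shows how quickly the numbers climb with chain size. A large drop is therefore expected, meaning stronger growth inhibition, though perhaps not all the way to compound 1.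

The expected change is a 9.2-fold lower number from compound 3 to compound 4 (0.96 log units; beyond the scatter). For compound 4 the estimated value is 1800 nM, with an expected range of 800 nM to 4500 nM.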

Compound 4, concentration for 50% growth inhibition: 2550 nM
Compound 4: middle estimate off by 1.4-fold (0.15 log units), on the low side; the measured number falls inside the stated range.
By their numbers in this assay, from the lowest: compound 1; then compound 4; then compounds 2 and 3 (each within the scatter of the next).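

In this assay, the shortened chain recovers much of the growth inhibition lost with the longer ones: a 6.5-fold lower number from compound 3 to compound 4 (0.81 log units; beyond the scatter), and likewise a 3.4-fold lower number from compound 2 to compound 4 (0.54 log units; beyond the scatter), so a long chain at this position is not needed for activity. The recovery is incomplete, with a 2.3-fold higher number from compound 1 to compound 4 (0.36 log units; beyond the scatter), so a single extra methyl already separates the two short chains, and the numbers rise in step with chain length from compound 1 through compound 4 to compound 2, with compound 3 carrying a terminal phenoxy group on its chain. Nothing available explains why the numbers rise as the chain grows.

Going by these compounds, it remains open whether a methyl group on the nitrogen would continue the trend toward lower numbers. On these data alone, it is also open whether an amine or a carboxylic acid at the end of the chain would be tolerated as poorly as the phenoxy group of compound 3.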